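Pyridinyl for pyrimidinyl on the piperazine of compound 2

The source may hold more compounds than are shown below. What is called first, only, known or untested is meant among the compounds shown, and "the series" means these compounds.

Measured compounds:
compound 1, `O=C(CN1CCN(c2ccccn2)CC1)Nc1cncnc1`, "not active" (no number reported);
compound 2, `Cc1cccc(NC(=O)CN2CCN(c3ncccn3)CC2)c1`, 197 nM.

In an assay on cells for antagonist activity at D(4) dopamine receptor (Homo sapiens), read by luminescence and beta-arrestin recruitment, with a stated time of 90 min (on this read-out higher numbers stand for weaker inhibition and lower numbers for stronger inhibition), compound 2 gives 197 nM. Compound 1, with its different amide portion, is recorded in this assay only as "not active" (no number reported), so the two values cannot be set side by side as a step, and compound 2 holds the only number shown. Compound 3, `Cc1cccc(NC(=O)CN2CCN(c3ccccn3)CC2)c1`, keeps the amide and phenyl portion of compound 2 and changes only the group on the piperazine: pyridin-2-yl in place of pyrimidin-2-yl on an amine nitrogen in a ring. Among the measured compounds shown here, no measured pair shows this change alone. With a single number on hand, the expected step from compound 2 to compound 3 is a 1.8-fold lower number from compound 2 to compound 3 (0.25 log units; within the scatter), in the direction of somewhat stronger inhibition, but small enough that it may not clear the scatter. Compound 3 is therefore estimated at 110 nM, in this assay, with a range from 30 nM to 500 nM.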

Compound 3, half-maximal inhibitory concentration: 313 nM
The estimate for compound 3 lay 2.8-fold (0.45 log units) below the measured number; the measured number falls inside the stated range.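

In this assay, among the compounds shown here, the first direct reading of this change on the amine nitrogen in a ring is a 1.6-fold higher number from compound 2 to compound 3 (0.20 log units; within the scatter), so on this read-out pyridin-2-yl and pyrimidin-2-yl cannot be told apart at this position. No measurement shown here explains this result. Compound 3 also gives a number while carrying the same pyridin-2-yl group as compound 1, so that group alone does not account for the record of compound 1, "not active" (no number reported), although no step involving that record can be read.

Going by these compounds, it remains open whether a phenyl group, or a simple chain such as ethyl, on the same nitrogen would give a number close to those of compound 2 and compound 3. On these data alone, the amide portion that separates compound 1 from compound 3 also remains open, with a single methyl-bearing phenyl example giving a number.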